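A few compounds are considered here, and "the series" means these few. Any claim that something is new, unique, unknown or untested is made for them only; others in the source may bear on it.

Measured so far:
- compound 1, `CNC(=O)N1CCCc2ccc(NC(=O)c3ccc(-c4ccn(C)n4)cc3)cc21`: 72.2%
- compound 2, `CNC(=O)N1CCCc2ccc(NC(=O)c3cccc(-c4cnn(C(C)=O)c4)c3)cc21`: 33.6%

Of the compounds shown here, two have been measured in a functional assay on MV4-11 cells (Homo sapiens) for antiproliferative activity, with a stated time of 6 days, tested at 1.56 uM; on this read-out higher numbers stand for a stronger effect at the one concentration tested and lower numbers for a weaker effect. Compound 1 gives 72.2%, which is the higher of the two numbers; compound 2 gives 33.6%, and the gap between them lies beyond the usual scatter of this kind of measurement. Compound 1 therefore stands at the top of what has been measured here.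

The next compound, compound 3, `CNC(=O)N1CCCc2ccc(NC(=O)c3ccc(-c4cccnc4)cc3)cc21`, keeps the shared core of compound 1 and changes one group on it:

pyridin-3-yl in place of 1-methyl-1H-pyrazol-3-yl on an aromatic carbon

Pyridin-3-yl thus takes the place of 1-methyl-1H-pyrazol-3-yl on an aromatic carbon, para to a large group. For the measured compounds named here, no pair of measured compounds that differ in exactly one place is available, so the size of such a swap cannot be read from the data. A moderate decrease in this assay seems the likelier outcome, though a change within the scatter is also possible; the step from compound 1 to compound 3 is expected to be a number 17.2 percentage points lower from compound 1 to compound 3 (beyond the scatter). Compound 3 is estimated at 55%, with a range from 25% to 80%.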

Compound 3, a percentage reported as inhibition, at one concentration (the size of the read-out at that concentration, not a potency): 62.5%
Estimate against measurement, compound 3: 7.5 percentage points below; low and high end bracket the measured number.
By their numbers in this assay, from the lowest: compound 2; then compounds 3 and 1 (each within the scatter of the next).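

In this assay, for the compounds shown here, putting pyridin-3-yl in place of 1-methyl-1H-pyrazol-3-yl on an aromatic carbon, para to a large group, gives a number 9.7 percentage points lower from compound 1 to compound 3 (within the scatter), and this is the first step here that isolates a single change. At this position, then, a six-membered aromatic ring with one hetero atom and a five-membered aromatic ring with two hetero atoms can be exchanged without the read-out moving beyond the usual scatter, so the data do not separate these two groups. No measured evidence is available to explain this result.

As far as these compounds go, both groups compared are aromatic rings, so it remains open how this carbon would respond to a non-aromatic group such as a morpholine ring, to a carboxylic acid, or to an open chain such as butyl. The read-out also comes from a single concentration, which leaves open whether the two compounds would match in potency across a full range of concentrations.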